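The source may report more compounds than this note shows. Statements on the series, on what has been measured and on what is new or still open speak of the compounds shown alone.

Compound 1 `COc1ccc(CNC(=O)c2cc(-c3cncc(C)c3)ncc2-c2cnn(C)c2)nc1OC` is tested in an assay on CHO cells for displacement of a labelled ligand from Orexin receptor type 2 (Homo sapiens), read by scintillation counting, with a stated time of 3 h (on this read-out lower numbers stand for stronger inhibition and higher numbers for weaker inhibition), where compound 1 gives 4.1 nM. Of the three numbers measured, compound 1 stands lowest. Within the data shown here, compound 2 `COc1ccc(CNC(=O)c2cc(-c3cncc(C)c3)ncc2-c2cncc(F)c2)nc1OC` gives 5.2 nM, and the step of a 1.3-fold higher number from compound 1 to compound 2 (0.10 log units; within the scatter) is the only single-point change measured on this core. Compound 3 `COc1ccc(CNC(=O)c2nc(-c3cncc(C)c3)ncc2-c2ccccc2)nc1OC` is not a single-point change from compound 1; in this assay compound 3 gives 11 nM, a weaker number than that of compound 1.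

Compound 4 `COc1ccc(CNC(=O)c2cc(-c3cncc(C)c3)ncc2-c2cnccn2)nc1OC` has not yet been measured. It differs from compound 1 by one change: pyrazin-2-yl in place of 1-methyl-1H-pyrazol-4-yl on an aromatic carbon. Among the measured compounds shown here, the measured step from compound 1 to compound 2 also exchanges the 1-methyl-1H-pyrazol-4-yl for a six-membered aromatic ring at the same place and stays within the scatter, so that step is the one that bears on compound 4. On that basis a step of a 1.5-fold higher number from compound 1 to compound 4 (0.17 log units; within the scatter) is expected, that is, no change beyond the scatter. Compound 4 is therefore estimated at 6 nM in this assay, with a range from 2.5 nM to 15 nM.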

Compound 4, inhibition constant: 7.6 nM
Compound 4: the middle estimate sits 1.3-fold (0.10 log units) below what was measured; measured number inside the range.
By their numbers in this assay, from the lowest: compounds 1, 2, 4 and 3 (each within the scatter of the next, the first and the last beyond it).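

In this assay, the step of a 1.9-fold higher number from compound 1 to compound 4 (0.27 log units; within the scatter) lies within the scatter, and so does the step of a 1.5-fold higher number from compound 2 to compound 4 (0.16 log units; within the scatter). At this carbon, ortho to a large group and para to a 5-methylpyridin-3-yl group, the five-membered 1-methyl-1H-pyrazol-4-yl and the six-membered 5-fluoropyridin-3-yl and pyrazin-2-yl therefore cannot be told apart, and the exchange of ring size at equal counts of heavy atoms and hydrogen-bond acceptors leaves no effect beyond the scatter. No independent measurement is available that would explain this flat result.

The compounds shown leave open how this position responds to a group other than an aromatic ring, such as a primary amine, a carboxylic acid or a longer alkyl chain. They also leave open whether the same flat response would hold on the core of compound 3, which differs from compound 1 in more than one place.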